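Swapping Chloro for Methoxy on the Pendant Phenyl Ring

A few compounds are considered here, and "the series" means these few. Any claim that something is new, unique, unknown or untested is made for them only; others in the source may bear on it.

Compound 1 `COc1cccc(C2C(=O)N(C)c3cnc(Nc4ccc(S(N)(=O)=O)cc4)nc3N2C)c1` gives 954 nM in an assay on Sf9 cells for inhibition of serine/threonine-protein kinase 4 (Homo sapiens), read by luminescence and ADP-Glo, with a stated time of 1 h, in the presence of a further agent that is not named here; on this read-out higher numbers stand for weaker inhibition and lower numbers for stronger inhibition.
Compound 2 `CN1C(=O)C(c2ccccc2F)N(C)c2nc(Nc3ccc(S(N)(=O)=O)cc3)ncc21` gives 75 nM.
Compound 3 `CN1C(=O)C(c2ccccc2Cl)N(C)c2nc(Nc3ccc(S(N)(=O)=O)cc3)ncc21` gives 129 nM.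

Compound 3 holds the second highest of the three numbers; it lies within the scatter of compound 2 and beyond the scatter below compound 1. Compound 4 `COc1ccccc1C1C(=O)N(C)c2cnc(Nc3ccc(S(N)(=O)=O)cc3)nc2N1C` differs from compound 3 by methoxy in place of chloro on an aromatic carbon. The measured steps of a 7.4-fold lower number from compound 1 to compound 3 (0.87 log units; beyond the scatter) and a 13-fold lower number from compound 1 to compound 2 (1.10 log units; beyond the scatter) show that replacing 3-methoxyphenyl by 2-chlorophenyl or 2-fluorophenyl lowers the number markedly, whereas a 1.7-fold higher number from compound 2 to compound 3 (0.24 log units; within the scatter) shows that exchanging one halogen for the other ortho to a large group changes little. For the measured compounds named here, no measured compound carries methoxy at that place, so this change is untested. Compound 4 is therefore expected near 250 nM, with a range from 80 nM to 800 nM. The expected step is a 1.9-fold higher number from compound 3 to compound 4 (0.29 log units; within the scatter).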

Compound 4, half-maximal inhibitory concentration: 251 nM
For compound 4 the middle estimate is 1.0-fold (0.00 log units) below the measured one, within the range that was stated.
By their numbers in this assay, from the lowest: compounds 2, 3 and 4 (each within the scatter of the next, the first and the last beyond it); then compound 1.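

Methoxy at this place, ortho to a large group, stays within the scatter of chloro (a 1.9-fold higher number from compound 3 to compound 4 (0.29 log units; within the scatter)). Against fluoro, the same group gives a step beyond the scatter (a 3.3-fold higher number from compound 2 to compound 4 (0.52 log units; beyond the scatter)), so the choice of group here can register even though the chloro step alone does not show it. With the same group on both sides, 2-methoxyphenyl in place of 3-methoxyphenyl also gives a step beyond the scatter (a 3.8-fold lower number from compound 1 to compound 4 (0.58 log units; beyond the scatter)), which isolates the effect of where the methoxy sits.

On these data alone, how an amine or a carboxylic acid at this place would read remains open. Nothing available explains any of these steps.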